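The source may hold more compounds than are shown below. What is called first, only, known or untested is meant among the compounds shown, and "the series" means these compounds.

In a functional assay (trachea) with Cavia porcellus as the target (on this read-out lower numbers stand for stronger inhibition and higher numbers for weaker inhibition), compound 1 (`CCCCn1nc(-c2cccnc2)c2ccccc2c1=O`) gives 2290 nM and compound 2 (`O=c1c2ccccc2c(-c2cccnc2)nn1C1CCCC1`) gives 2750 nM, so the two values lie within the scatter of each other. Compound 3 (`O=c1c2ccccc2c(-c2cccnc2)nn1Cc1ccccc1`) has not yet been measured. Its difference from compound 1 is phenyl in place of propyl on a saturated chain carbon bound to an aromatic nitrogen, with phenyl in place of propyl on a saturated chain carbon bound to an aromatic nitrogen. Among the compounds with values here, the one measured step that bears on this change, a 1.2-fold higher number from compound 1 to compound 2 (0.08 log units; within the scatter), is small, so no shift beyond the scatter is expected in this assay. The expected change is a 1.1-fold lower number from compound 1 to compound 3 (0.06 log units; within the scatter). For compound 3, the estimated value is 2000 nM, with an expected range of 700 nM to 6000 nM.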

Compound 3, half-maximal inhibitory concentration: 2450 nM
Estimate against measurement, compound 3: 1.2-fold (0.09 log units) below; the range from low to high includes it.
By their numbers in this assay, from the lowest: compounds 1, 3 and 2 (each within the scatter of the next).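

In this assay, benzyl in place of butyl gives a 1.1-fold higher number from compound 1 to compound 3 (0.03 log units; within the scatter), and benzyl in place of cyclopentyl gives a 1.1-fold lower number from compound 2 to compound 3 (0.05 log units; within the scatter). A six-membered aromatic ring of carbon only can therefore enter at this place without a shift beyond the scatter, which the earlier pair, neither member of which carries such a ring, could not show. Nothing measured accounts for how alike the three values are. On these data alone, whether an amine, a carboxylic acid or a longer chain on the aromatic nitrogen would move the number beyond the scatter stays open.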